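Shortening the chain at the carbon between two ring nitrogens

The compounds below may be only part of what the source reports. "The series", "measured", "known", "first", "only" and "open" are said of these compounds alone.

Measured compounds:
compound 1 `Nc1ncnc2c1nc(O)n2Cc1ccc(Cl)cc1` 30 mg/kg
compound 2 `CCCCCNc1nc(N)c2nc(O)n(Cc3ccccc3)c2n1` 0.3 mg/kg
compound 3 `CCCCSc1nc(N)c2nc(O)n(Cc3ccccc3)c2n1` 0.3 mg/kg

In a functional assay on the whole organism for activation, with Mus musculus as the target (on this read-out lower numbers stand for an effect already at smaller amounts and higher numbers for an effect only at larger amounts of compound), compound 2 gives 0.3 mg/kg and stands level with compound 3, which gives 0.3 mg/kg; compound 1, with 30 mg/kg, lies far away, but it differs from compound 2 in two places, so its values alone show only that a large gap exists. Compound 4 `CCCc1nc(N)c2nc(O)n(Cc3ccccc3)c2n1` has not yet been measured. Its difference from compound 2 is propyl in place of pentylamino on an aromatic carbon. Among the measured compounds shown here, the only measured step at that carbon, no change at the digits printed from compound 2 to compound 3 (within the scatter), shows that exchanging one chain with a heteroatom link for another leaves this assay unchanged. For the measured compounds named here, no measured pair, however, tests a plain propyl chain at this carbon, nor the loss of the hydrogen-bond donor and acceptor counted above, so compound 1 offers no guidance either. Compound 4 is therefore expected to give 1 mg/kg, with a range from 0.3 mg/kg to 10 mg/kg, the step of a 3.3-fold higher number from compound 2 to compound 4 (0.52 log units; beyond the scatter) being expected as a modest loss.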

Compound 4, minimum effective dose: 3 mg/kg
Estimate against measurement, compound 4: 3.0-fold (0.48 log units) below, and the stated range covers the measured number.
By their numbers in this assay, from the lowest: compounds 2 and 3 (each within the scatter of the next); then compound 4; then compound 1.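

The carbon between two ring nitrogen atoms turns out not to accept every chain alike. In this assay, exchanging pentylamino for butylsulfanyl had given no change at the digits printed from compound 2 to compound 3 (within the scatter), whereas propyl in place of pentylamino gives a 10-fold higher number from compound 2 to compound 4 (1.00 log units; beyond the scatter), and propyl in place of butylsulfanyl gives a 10-fold higher number from compound 3 to compound 4 (1.00 log units; beyond the scatter), so the tolerance seen so far does not extend to this plain, shorter chain. No measurement on hand explains this loss.

Propyl differs from both other groups in chain length and in lacking a linking heteroatom, so these compounds cannot show which of the two matters. As far as these compounds go, a pentyl chain joined directly through carbon, or a propylamino or propylsulfanyl group at this carbon, would separate the two, and the effect of a butoxy link remains open as well.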